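Extending the Chain in a Hexokinase-1 Compound Pair

The source may hold more compounds than are shown below. What is called first, only, known or untested is meant among the compounds shown, and "the series" means these compounds.

Measured so far:
compound 1, `O=C(CI)NCCCCCCCCNc1ncnc2c1ncn2[C@@H]1O[C@H](COP(=O)(O)OP(=O)(O)OP(=O)(O)O)[C@@H](O)[C@H]1O` — 35%
compound 2, `CN(CCCCN(C)c1ncnc2c1ncn2[C@@H]1O[C@H](COP(=O)(O)OP(=O)(O)OP(=O)(O)O)[C@@H](O)[C@H]1O)C(=O)CCCNC(=O)CI` — 0%

Of the compounds shown here, two have been tested in an assay on isolated protein for inhibition of hexokinase-1 (Rattus norvegicus), with a stated time of 6 h, tested at 10 mM; a higher number here means more inhibition at the concentration tested (going by the name of the read-out), a lower number less inhibition. Compound 1 `O=C(CI)NCCCCCCCCNc1ncnc2c1ncn2[C@@H]1O[C@H](COP(=O)(O)OP(=O)(O)OP(=O)(O)O)[C@@H](O)[C@H]1O` gives 35%, the higher of the two numbers. Compound 2 `CN(CCCCN(C)c1ncnc2c1ncn2[C@@H]1O[C@H](COP(=O)(O)OP(=O)(O)OP(=O)(O)O)[C@@H](O)[C@H]1O)C(=O)CCCNC(=O)CI` gives 0%, a result that lies beyond the scatter below compound 1. Going by the values given here, the two share the same core carrying the triphosphate sugar, but they differ in several places at once, so their pair gives no single-change step; all that can be said is what the two values show.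

Compound 3 `O=C(CI)NCCC(=O)NCCCCCCNc1ncnc2c1ncn2[C@@H]1O[C@H](COP(=O)(O)OP(=O)(O)OP(=O)(O)O)[C@@H](O)[C@H]1O` is not yet measured. It differs from compound 1 as follows: a group of 10 heavy atoms (5 carbon, 2 nitrogen, 2 oxygen, 1 iodine; no ring) in place of a group of 7 heavy atoms (4 carbon, 1 nitrogen, 1 oxygen, 1 iodine; no ring), on a saturated chain carbon, six bonds along the chain from a nitrogen on an aromatic ring. Among the compounds with values here, no step between measured compounds that differ in one place is available, so the size of this step has no precedent in the set. The change is expected to shift the inhibition by a small amount, most likely downward or not beyond the scatter, since compound 1 with 35% is the only anchor. For compound 3 the expected step from compound 1 is a number 10 percentage points lower from compound 1 to compound 3 (within the scatter), with the estimate set at 25% within a range of 5% to 50%.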

Compound 3, a percentage reported as inhibition, at one concentration (the size of the read-out at that concentration, not a potency): 0%
Beside the measured number, compound 3's estimate is 25 percentage points above it; the whole stated range lies above it.
By their numbers in this assay, from the lowest: compounds 2 and 3 (each within the scatter of the next); then compound 1.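

The exchange gives the set its first step at a single place: in this assay, a number 35 percentage points lower from compound 1 to compound 3 (beyond the scatter). This shows that, on a saturated chain carbon six bonds along the chain from a nitrogen on an aromatic ring, the 2-(((iodomethyl)carbonyl)amino)ethyl group cannot be replaced by this larger group of 10 heavy atoms without a clear effect on the read-out, something the earlier pair, which differs in several places at once, could not isolate. Nothing measured here accounts for the drop.

Going by these compounds alone, the single step changes the heavy-atom count, the double bonds outside aromatic rings, and the hydrogen-bond donors and acceptors together, so it does not show which of these differences matters. A plain longer all-carbon chain carrying the same iodomethyl carbonyl end, or a shorter chain at this place, would be needed to tell whether chain length alone or the added nitrogen and oxygen goes with the step.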